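Working notes on the shared core: compound 1 toward compound 4

A few compounds are considered here, and "the series" means these few. Any claim that something is new, unique, unknown or untested is made for them only; others in the source may bear on it.

Measured so far:
compound 1 `Nc1nc(-c2ccc(C(F)F)o2)nc2sc(Cc3ccccc3)cc12` — 3000 nM
compound 2 `COc1ccccc1Cc1cc2c(N)nc(-c3ccc(C(F)F)o3)nc2s1` — 516 nM
compound 3 `C=C(c1ccccc1)c1cc2c(N)nc(-c3nc(C)cs3)nc2s1` — > 594 nM, a limit only

In a functional assay on CHO-K1 cells for antagonist activity at adenosine receptor A1 (Homo sapiens), read by a beta-galactosidase reporter and cAMP accumulation, with stated times of 15 min and 6 h (on this read-out higher numbers stand for weaker inhibition and lower numbers for stronger inhibition), compound 1 stands at the highest of the two numbers; its nearest neighbour is compound 2, reached by a 5.8-fold lower number from compound 1 to compound 2 (0.76 log units; beyond the scatter) through methoxy in place of hydrogen on an aromatic carbon. For compound 3 this assay reports the limit of > 594 nM in this assay, at which 1 of the 3 values shown sits, and no number.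

Compound 4 `N#Cc1cccc(-c2nc(N)c3cc(Cc4ccccc4)sc3n2)n1` differs from compound 1 by 6-cyanopyridin-2-yl in place of 5-(difluoromethyl)furan-2-yl on an aromatic carbon. Going by the values given here, the only measured step concerns the benzyl position, not the position changed here; compound 3 carries a different group at that position but gives only a limit. Among the compounds with values here, no measured step therefore bears on this change, and no step beyond the scatter is expected: from compound 1 to compound 4 the expected step is a 1.2-fold lower number from compound 1 to compound 4 (0.08 log units; within the scatter). Compound 4 is estimated at 2500 nM, within 500 nM to 12000 nM.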

Compound 4, inhibition constant: > 1000 nM
Compound 4: no number, only a limit; the forecaster's own chance of this, stated with the estimate: 25%; the middle value is on the limit's open side.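

In this assay compound 4 gives > 1000 nM, a limit and not a number, so the step from compound 1 to compound 4 cannot be read. The compounds shown leave open how 6-cyanopyridin-2-yl compares with 5-(difluoromethyl)furan-2-yl on the shared core.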